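Replacing bromo by tert-butyl on the thioether aryl ring

The source may report more compounds than this note shows. Statements on the series, on what has been measured and on what is new or still open speak of the compounds shown alone.

Compound 1 `Nc1ccccc1NC(=O)c1ccc(CSc2ccc(Br)cc2)cc1` gives 9.96% in a functional assay on HCT-116 cells (Homo sapiens) for inhibition, read by CCK-8 assay, with a stated time of 72 h, tested at 2 uM; on this read-out lower numbers stand for less inhibition of growth and higher numbers for more inhibition of growth at the one concentration tested.
Compound 2 `Nc1ccccc1NC(=O)/C=C/c1ccc(CSc2ccc(Cl)cc2)cc1` gives 5.62% in this assay.
Compound 3 `CC(C)(C)c1ccc(SCc2ccc(/C=C/C(=O)Nc3ccccc3N)cc2)cc1` gives 6.66% in this assay.

The three numbers lie close together: compound 1 stands apart from compound 3 and from compound 2 only by amounts that fall within the usual scatter, so none of the three can be set above the others on this read-out.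

Compound 4 `CC(C)(C)c1ccc(SCc2ccc(C(=O)Nc3ccccc3N)cc2)cc1` differs from compound 1 in a single place (tert-butyl in place of bromo on an aromatic carbon). The closest guide among the measured pairs is the step from compound 2 to compound 3, which share a core that differs from that of compound 1 but carry the same exchange of a halogen for tert-butyl on the same ring: there a number 1 percentage points higher from compound 2 to compound 3 (within the scatter). That single comparison gives no sign of a shift beyond the scatter, and nothing else in the data speaks to this change.

Compound 4 is therefore expected to land where compound 1 already sits, with a number 0 percentage points higher from compound 1 to compound 4 (within the scatter) foreseen as no more than the scatter. The estimate for compound 4 in this assay is 10%, within a range from 0% to 22%.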

Compound 4, percent growth inhibition at one concentration: 4.81%
Compound 4: middle estimate off by 5.2 percentage points, on the high side; low and high end bracket the measured number.
By their numbers in this assay, from the lowest: compounds 4, 2, 3 and 1 (each within the scatter of the next).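

On the core of compound 1, tert-butyl in place of bromo gives a number 5.2 percentage points lower from compound 1 to compound 4 (within the scatter) in this assay, so this aromatic carbon carries either group without a shift beyond the scatter. Together with a number 1 percentage points higher from compound 2 to compound 3 (within the scatter), this means the exchange of a halogen for tert-butyl now stays within the scatter on both cores shown, where previously only one core spoke to it. No measurement shown bears on the reason for this result.

The compounds shown leave open whether an amine or a carboxylic acid on this aromatic carbon would move the number beyond the scatter in this assay on either core. They also leave open whether a methoxy group or a plain hydrogen at the same place would separate itself from bromo, chloro and tert-butyl, since these three groups have so far given numbers that cannot be told apart at the one concentration tested.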